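The compounds below may be only part of what the source reports. "The series", "measured", "known", "first", "only" and "open" are said of these compounds alone.

Three compounds were measured in a functional assay on A549 cells (Homo sapiens) for antiproliferative activity, read by MTT assay, with a stated time of 48 h, in the presence of a further agent that is not named here; a lower number here means a stronger inhibitor of growth, a higher number a weaker inhibitor of growth:

Compound 1 `O=C(NOCc1ccccc1F)c1cn(-c2ccccc2)nc1-c1ccccc1` gives 5940 nM.
Compound 2 `O=C(NOCc1ccccc1Cl)c1cn(-c2ccccc2)nc1-c1ccccc1` gives 10300 nM.
Compound 3 `O=C(NOCc1ccccc1)c1cn(-c2ccccc2)nc1-c1ccc(Cl)cc1` gives 13000 nM.

Compound 2 and compound 1 differ in one place, (fluoro in place of chloro on an aromatic carbon), and this change made a 1.7-fold lower number from compound 2 to compound 1 (0.24 log units; within the scatter). Compound 3 and compound 2 are built from the same atoms joined differently; the difference between the two cores is not broken down here. Compound 4 `O=C(NOCc1ccccc1)c1cn(-c2ccccc2)nc1-c1ccc(F)cc1` has not yet been measured; it differs from compound 3 by fluoro in place of chloro on an aromatic carbon. The two places are not the same: in the earlier pair the exchanged atom sits ortho to a large group, here it sits para to a large group, so this is the same kind of change rather than the same change. From compound 3 to compound 4 a step of a 1.4-fold lower number from compound 3 to compound 4 (0.14 log units; within the scatter) is expected in this assay, resting on the small step of a 1.7-fold lower number from compound 2 to compound 1 (0.24 log units; within the scatter). Compound 4 is therefore estimated at 9500 nM, likely between 4000 nM and 25000 nM.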

Compound 4, concentration for 50% growth inhibition: 10400 nM
For compound 4 the middle estimate is 1.1-fold (0.04 log units) below the measured one, within the range that was stated.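

In this assay, going from 4-chlorophenyl to 4-fluorophenyl gave a 1.3-fold lower number from compound 3 to compound 4 (0.10 log units; within the scatter). Set beside the earlier exchange, the same kind of change at a different place on a different core shows no detectable difference between the two steps: the same change on two cores in this assay, a 1.7-fold lower number (0.24 log units; within the scatter) from compound 2 to compound 1 and a 1.3-fold lower number (0.10 log units; within the scatter) from compound 3 to compound 4, 1.4-fold (0.14 log units) apart, within the scatter of two such steps This agreement means only that the exchange carried across these two cores without a visible shift; since each step lies within the scatter, it does not show that fluoro in place of chloro really changes growth inhibition on either core.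

The compounds shown carry only fluoro or chloro as ring substituents. From the compounds shown here alone, what a larger change would do at these places, such as a methoxy group, a nitrile or an amine, remains open.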